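Amide Aryl Swap on a Fluoroquinolone Scaffold

The source may report more compounds than this note shows. Statements on the series, on what has been measured and on what is new or still open speak of the compounds shown alone.

Compound 1 `CCn1cc(-c2nc3ccc([N+](=O)[O-])cc3o2)c(=O)c2cc(F)c(N3CCNC(C)C3)c(F)c21`: 900 nM
Compound 2 `CCn1cc(C(=O)Nc2ccccc2O)c(=O)c2cc(F)c(N3CCNC(C)C3)c(F)c21`: 5050 nM

Of the compounds shown here, two have been measured in a functional assay on KB cells (Homo sapiens) for cytotoxicity, read by MTT assay; on this read-out lower numbers stand for stronger inhibition and higher numbers for weaker inhibition. Compound 1 gives 900 nM in this assay. Compound 2 carries a 2-hydroxyphenyl amide in place of the nitro-substituted benzoxazole of compound 1; in this assay compound 2 gives 5050 nM, the higher of the two numbers and beyond the scatter from compound 1. Within the data shown here, no single-point step connects the two, so their values can only be set side by side.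

Compound 3 `CCn1cc(C(=O)Nc2ccc(C)c([N+](=O)[O-])c2)c(=O)c2cc(F)c(N3CCNC(C)C3)c(F)c21` differs from compound 2 in one place: 4-methyl-3-nitrophenyl in place of 2-hydroxyphenyl on an amide-type nitrogen. Among the measured compounds shown here, no measured pair shows this change, so its effect cannot be read from the data. For the measured compounds named here, a moderate decrease in the number is expected for compound 3, of a size around the edge of the scatter, since compound 1, the only other measured compound and the lower of the two at 900 nM, also carries a nitro group on its aromatic substituent. The expected step is a 2.0-fold lower number from compound 2 to compound 3 (0.31 log units; beyond the scatter). Compound 3 is therefore estimated at 2500 nM, with a range from 800 nM to 8000 nM.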

Compound 3, half-maximal inhibitory concentration: 3900 nM
Compound 3: the middle estimate sits 1.6-fold (0.19 log units) below what was measured; measured number inside the range.
By their numbers in this assay, from the lowest: compound 1; then compounds 3 and 2 (each within the scatter of the next).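

In this assay, among these compounds, the step at the amide-type nitrogen is a 1.3-fold lower number from compound 2 to compound 3 (0.11 log units; within the scatter), the first measured step at this place on the shared core, and it leaves the two compounds indistinguishable. The change is not a small one on paper: 4-methyl-3-nitrophenyl counts more heavy atoms than 2-hydroxyphenyl, brings a nitro group and a methyl group, and has no hydrogen-bond donor where the leaving group has one, yet none of this moves the number past the usual scatter, so at this place in these two compounds the read-out does not separate the two aryl groups. No measurement of any other kind bears on this result.

Since the hydroxyl, the nitro group and the methyl group all change in a single step, the compounds shown do not say whether each alone would be as silent or whether their contributions offset one another. An unsubstituted phenyl, a single nitrophenyl or an aryl ring carrying an amine or a carboxylic acid at this amide nitrogen would remain to be read, and so would a non-aromatic group such as a longer alkyl chain.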